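The source may report more compounds than this note shows. Statements on the series, on what has been measured and on what is new or still open speak of the compounds shown alone.

Compound 1 `Cc1c(C(=O)Nc2ccc(Oc3ccnc4[nH]ccc34)c(F)c2)nnn1-c1ccccc1` carries a methyl group on the five-membered ring of the shared core. In a functional assay on A549 cells (Homo sapiens) for cytotoxicity, read by MTT assay, with a stated time of 72 h (on this read-out higher numbers stand for weaker inhibition and lower numbers for stronger inhibition), compound 1 gives 360 nM, the second highest of the three numbers shown, although compound 3 sits within the scatter of it. Compound 2 `Cc1c(C(=O)Nc2ccc(Oc3ccnc4[nH]ccc34)c(F)c2)nnn1-c1ccc(F)cc1` gives 150 nM, and compound 3 `Cc1c(C(=O)Nc2ccc(Oc3ccnc4[nH]ccc34)cc2)nnn1-c1ccccc1` gives 420 nM. The step of a 2.4-fold lower number from compound 1 to compound 2 (0.38 log units; beyond the scatter) is modest yet beyond the scatter, whereas a 1.2-fold higher number from compound 1 to compound 3 (0.07 log units; within the scatter) stays within it. Compound 4 `O=C(Nc1ccc(Oc2ccnc3[nH]ccc23)c(F)c1)c1nnn(-c2ccccc2)c1C(F)(F)F` differs from compound 1 by trifluoromethyl in place of methyl on an aromatic carbon. Neither measured step touches this methyl group; both swap a fluorine for a hydrogen elsewhere, so they offer only loose guidance. No step beyond the scatter is therefore expected in this assay for compound 4, in either direction. Compound 4 is estimated at 400 nM, with a range from 150 nM to 1100 nM. This estimate means a 1.1-fold higher number from compound 1 to compound 4 (0.05 log units; within the scatter) is expected.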

Compound 4, half-maximal inhibitory concentration: 220 nM
Compound 4: the middle estimate sits 1.8-fold (0.26 log units) above what was measured, within the range that was stated.
By their numbers in this assay, from the lowest: compounds 2, 4, 1 and 3 (each within the scatter of the next, the first and the last beyond it).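

Compound 4 is the first change shown at this position, on an aromatic carbon of the five-membered ring, and in this assay trifluoromethyl in place of methyl gives a 1.6-fold lower number from compound 1 to compound 4 (0.21 log units; within the scatter). This carbon, next to the ring atom that bears a phenyl group, therefore tolerates this swap with no step beyond the scatter. Nothing measured here explains the result. Still open, as far as these compounds go, is how the same position would respond to an amine, a carboxylic acid or a longer chain, and whether the fluoro on the other phenyl ring, as in compound 2, would add to trifluoromethyl.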